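The source may hold more compounds than are shown below. What is called first, only, known or untested is meant among the compounds shown, and "the series" means these compounds.

Compounds measured in a functional assay on SK-OV-3 cells (Homo sapiens) for antiproliferative activity, with a stated time of 48 h; on this read-out lower numbers stand for stronger inhibition of growth and higher numbers for weaker inhibition of growth:
Compound 1, `Cc1cc(O)c(C2=NN(c3ccc(S(N)(=O)=O)cc3)C(c3ccccc3O)C2)cc1Cl`, gives 14900 nM.
Compound 2, `Cc1cc(O)c(C2=NN(c3ccc(S(N)(=O)=O)cc3)C(c3ccccc3Cl)C2)cc1Cl`, gives 10400 nM.
Compound 3, `Cc1cc(O)c(C2=NN(c3ccc(S(N)(=O)=O)cc3)C(/C=C/c3ccccc3)C2)cc1Cl`, gives 17900 nM.

In this assay the three numbers sit close together. Compound 3 is separated from the others only by a 1.2-fold higher number from compound 1 to compound 3 (0.08 log units; within the scatter) and by a 1.7-fold higher number from compound 2 to compound 3 (0.24 log units; within the scatter), and the pair of compounds 1 and 2 differs by a 1.4-fold lower number from compound 1 to compound 2 (0.16 log units; within the scatter); none of these gaps exceeds the scatter, so the three compounds cannot be told apart on this read-out.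

Compound 4, `COc1ccc(C2CC(c3cc(Cl)c(C)cc3O)=NN2c2ccc(S(N)(=O)=O)cc2)cc1OC`, has not yet been measured. It differs from compound 3 in one place: 3,4-dimethoxyphenyl in place of 2-phenylethenyl on a saturated ring carbon. The two measured steps that bear on this position are those from compound 1 and from compound 2 to compound 3, both exchanging the group on the same saturated ring carbon, and both stayed within the scatter. On that basis the step from compound 3 to compound 4 is expected to be a 1.2-fold lower number from compound 3 to compound 4 (0.08 log units; within the scatter), with no clear direction. For compound 4 the estimate in this assay is 15000 nM, with a range from 6000 nM to 40000 nM.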

Compound 4, concentration for total growth inhibition: 38300 nM
Beside the measured number, compound 4's estimate is 2.6-fold (0.41 log units) below it; the range from low to high includes it.
By their numbers in this assay, from the lowest: compounds 2, 1 and 3 (each within the scatter of the next); then compound 4.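

In this assay the saturated ring carbon of the five-membered ring now shows a response to what it carries: 3,4-dimethoxyphenyl gives a 2.1-fold higher number from compound 3 to compound 4 (0.33 log units; beyond the scatter), a 2.6-fold higher number from compound 1 to compound 4 (0.41 log units; beyond the scatter) and a 3.7-fold higher number from compound 2 to compound 4 (0.57 log units; beyond the scatter), each modest but beyond the scatter, whereas the exchanges among 2-hydroxyphenyl, 2-chlorophenyl and 2-phenylethenyl all stayed within it. Of the four compounds, compound 4 is therefore the weakest inhibitor of growth on this read-out. No measurement at hand explains this shift.

From the compounds shown here alone, it remains open whether both methoxy groups are needed for the shift, or whether a single 4-methoxyphenyl or 3-methoxyphenyl group at this carbon would give the same result. Also open, going by these compounds, is how an unsubstituted phenyl or a 4-aminophenyl group would compare there.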